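The source may hold more compounds than are shown below. What is called first, only, known or untested is meant among the compounds shown, and "the series" means these compounds.

In a functional assay on MDA-MB-231 cells (Homo sapiens), read by microscopy and transwell migration, with a stated time of 24 h (a higher number here means a weaker inhibitor, a lower number a stronger inhibitor), compound 1 `O=C(Nc1nc(-c2cccc(Br)c2)cs1)c1ccccc1` gives 10000 nM and compound 2 `O=C(Nc1nc(-c2ccc(Br)cc2)cs1)c1ccccc1` gives 9500 nM, so compound 2 stands level with compound 1 within the scatter. Compound 3 `O=C(Nc1nc(-c2cccc(Cl)c2)cs1)c1ccccc1` carries 3-chlorophenyl in place of 4-bromophenyl on an aromatic carbon. Among the measured compounds shown here, only one measured step bears on this change: a 1.1-fold lower number from compound 1 to compound 2 (0.02 log units; within the scatter), with 4-bromophenyl in place of 3-bromophenyl, and it stays within the scatter. For the measured compounds named here, no measured pair shows chlorine in place of bromine. The expected result is a 1.1-fold lower number from compound 2 to compound 3 (0.02 log units; within the scatter), with no shift beyond the scatter anticipated in either direction. For compound 3 the estimate is 9000 nM, with an expected range of 4000 nM to 20000 nM.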

Compound 3, half-maximal inhibitory concentration: 123 nM
For compound 3 the middle estimate is 73-fold (1.86 log units) above the measured one, outside the stated range (below it).
By their numbers in this assay, from the lowest: compound 3; then compounds 2 and 1 (each within the scatter of the next).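

Which halogen sits on the phenyl group matters far more here than where the bromine sits. In this assay, chloro in place of bromo gives an 81-fold lower number from compound 1 to compound 3 (1.91 log units; beyond the scatter) even though nothing else changes, while the earlier swap between 3-bromophenyl and 4-bromophenyl stayed within the scatter. The change from 4-bromophenyl to 3-chlorophenyl gives a similarly large a 77-fold lower number from compound 2 to compound 3 (1.89 log units; beyond the scatter) and so a single halogen atom can carry a large step in this series. No evidence at hand explains this gap.

Going by these compounds, it remains open whether 4-chlorophenyl would match 3-chlorophenyl, and whether 3-fluorophenyl or 3-methoxyphenyl would hold the low number.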